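This account rests on a few compounds, and the source may have more. Where it says the series, first, only, none or still open, it means among the compounds named here.

Working notes on the series in a functional assay on A549 cells (Homo sapiens) for inhibition, read by MTT assay, with a stated time of 48 h; on this read-out lower numbers stand for stronger inhibition and higher numbers for weaker inhibition. Compound 1 `COc1cc(-c2nccn3cc(-c4ccc(F)cc4)nc23)cc(OC)c1OC`, carrying fluoro, gives 137 nM. Compound 2 `COc1cc(-c2nccn3cc(-c4ccc([N+](=O)[O-])cc4)nc23)cc(OC)c1OC`, carrying nitro, gives > 10000 nM, which is a limit. Compound 3 `COc1cc(-c2nccn3cc(-c4ccc(C(F)(F)F)cc4)nc23)cc(OC)c1OC`, carrying trifluoromethyl, gives > 10000 nM, which is also a limit and not a number. Compound 3 therefore stands at the limit of > 10000 nM in this assay, at which 2 of the 3 values shown sit.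

Compound 4 `COc1cc(-c2nccn3cc(-c4ccc(O)cc4)nc23)cc(OC)c1OC` is the next entry, with hydroxy in place of trifluoromethyl on an aromatic carbon, para to a large group: hydroxy in place of trifluoromethyl on an aromatic carbon.

For the measured compounds named here, two measured steps bear on this change, both large and both starting from compound 1: an at least 72-fold higher number from compound 1 to compound 2 (1.86 log units; beyond the scatter) and an at least 72-fold higher number from compound 1 to compound 3 (1.86 log units; beyond the scatter). Neither tests hydroxy. The remaining comparison is a step that the two limits leave unreadable from compound 2 to compound 3.

Going by the values given here, with compound 1 at 137 nM as the only number, a moderate move to a lower number is expected in this assay. A return to the limit remains possible. The expected step is an at least 6.6-fold lower number from compound 3 to compound 4 (0.82 log units; beyond the scatter). For compound 4 the estimate is 1500 nM, with an expected range of 200 nM to 10000 nM.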

Compound 4, half-maximal inhibitory concentration: > 10000 nM
Compound 4: no number, only a limit; the forecaster's own chance of this, stated with the estimate: 30%; middle value at least 6.6-fold (0.82 log units) from the limit.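

Hydroxy at this position, para to a large group, falls with nitro and trifluoromethyl on the same side of fluoro in this assay, and the one readable step is an at least 72-fold higher number from compound 1 to compound 4 (1.86 log units; beyond the scatter). Compound 4 gives a limit and not a number, so its steps to compound 2 and compound 3 cannot be read. Swapping trifluoromethyl for hydroxy, which adds a hydrogen-bond donor, does not bring the series off the limit, and of the four groups only fluoro in compound 1 gives a number: the limit of > 10000 nM in this assay, at which 3 of the 4 values shown sit.

On these data alone, how far compound 2, compound 3 and compound 4 lie from one another remains open. Also open, as far as these compounds go, is whether the number belongs to fluoro alone or would also hold with chloro, methyl or an amine at this position.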